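The source may hold more compounds than are shown below. What is called first, only, known or untested is meant among the compounds shown, and "the series" means these compounds.

Compound 1 `CCOC(=O)C1CN(C(C)=O)CCN1S(=O)(=O)c1ccc(F)cc1` is one of two compounds tested in a functional assay on the whole organism (strain CD-1) with Mus musculus as the target, with a stated time of 20 min; on this read-out higher numbers stand for an effect only at larger amounts of compound and lower numbers for an effect already at smaller amounts. In this assay compound 1 gives 0.1 mg/kg, the lowest number of the two. The only companion, compound 2 `CC(=O)N1CCN(S(=O)(=O)c2ccc(F)cc2)CC1CO`, gives 10 mg/kg in this assay, a much higher number, and the gap between the two compounds lies well beyond the usual scatter. Within the data shown here, nothing else has been measured, so no step between measured compounds can be traced.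

Compound 3 `CC(=O)OCC1CN(C(C)=O)CCN1S(=O)(=O)c1ccc(F)cc1` has not yet been measured in this assay. It differs from compound 1 in one place (acetoxymethyl in place of ethoxycarbonyl on a saturated ring carbon), and the two compounds carry the same atoms joined differently. Among the measured compounds shown here, with only two measured values at hand and no measured step to lean on, the expected step is a 10-fold higher number from compound 1 to compound 3 (1.00 log units; beyond the scatter). Compound 3 is therefore estimated to give 1 mg/kg in this assay, with a plausible range from 0.1 mg/kg to 10 mg/kg.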

Compound 3, minimum effective dose: 0.1 mg/kg
For compound 3 the middle estimate is 10-fold (1.00 log units) above the measured one; measured number inside the range.
By their numbers in this assay, from the lowest: compounds 1 and 3 (each within the scatter of the next); then compound 2.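

Acetoxymethyl in place of ethoxycarbonyl on this saturated ring carbon brings no change at the digits printed from compound 1 to compound 3 (within the scatter) in this assay and is the first step at this position that can be read at all. The two groups carry the same heavy atoms and the same counts of hydrogen-bond donors and acceptors, and joining those atoms differently on this carbon leaves the minimum effective dose unmoved, so at this position the read-out does not separate the two arrangements. Nothing at hand speaks to why the two groups read alike.

On these data alone, whether this holds for groups of another kind on the same ring carbon stays open, as a carboxylic acid, a primary amine or a longer chain such as butoxycarbonyl might read quite differently in this assay on this position. Also open, as far as these compounds go, is whether the match between ethoxycarbonyl and acetoxymethyl would survive a change elsewhere on the shared core, for instance a benzoyl group in place of the acetyl group.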